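The compounds below may be only part of what the source reports. "The series", "measured", "known", "first", "only" and "open" are said of these compounds alone.

Compound 1 `COc1cc2ncnc(Nc3ccc(NC(=O)c4ccc(C)cc4)cc3)c2cc1OC` is the starting point of this comparison. In a functional assay on MCF7 cells (Homo sapiens) for inhibition, read by MTT assay (a higher number here means a weaker inhibitor, a lower number a stronger inhibitor), compound 1 gives 19000 nM. Compound 3 `COc1cc2ncnc(Nc3ccc(NC(=O)c4ccccc4Cl)cc3)c2cc1OC` carries 2-chlorophenyl in place of 4-methylphenyl on the carbonyl carbon, and in this assay compound 3 gives 36000 nM; the step of a 1.9-fold higher number from compound 1 to compound 3 (0.28 log units; within the scatter) separates the two. Compound 2 `COc1cc2ncnc(Nc3ccc(NC(=O)c4ccccc4OC)cc3)c2cc1OC`, with 2-methoxyphenyl on the carbonyl carbon, reaches only the limit of the assay at > 100000 nM. That limit is the limit of > 100000 nM in this assay, at which 1 of the 3 values shown sits. From compound 1 the move to compound 2 reads an at least 5.2-fold higher number from compound 1 to compound 2 (0.72 log units; beyond the scatter), and the move from compound 2 to compound 3 reads an at least 2.7-fold lower number from compound 2 to compound 3 (0.44 log units; beyond the scatter).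

Compound 4 `COc1cc2ncnc(Nc3ccc(NC(=O)c4ccc(Cl)cc4)cc3)c2cc1OC` differs from compound 1 by chloro in place of methyl on an aromatic carbon. Among the measured compounds shown here, no measured step exchanges methyl for chloro at this position. The step of a 1.9-fold higher number from compound 1 to compound 3 (0.28 log units; within the scatter) shows that a chlorine on the phenyl ring, at a different place, leaves the number within the scatter, whereas the limit of compound 2 points to the methoxy group rather than to the chlorine. Compound 4 is therefore expected to give 25000 nM, between 10000 nM and 60000 nM. This estimate corresponds to a step of a 1.3-fold higher number from compound 1 to compound 4 (0.12 log units; within the scatter), expected to fall within the scatter.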

Compound 4, half-maximal inhibitory concentration: 30000 nM
Compound 4: middle estimate off by 1.2-fold (0.08 log units), on the low side, within the range that was stated.
By their numbers in this assay, from the lowest: compounds 1, 4 and 3 (each within the scatter of the next). At a limit, above all of these: compound 2.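

In this assay, methyl and chloro on the aromatic carbon para to a large group can now be compared directly, and moving the chlorine from 2-chlorophenyl to 4-chlorophenyl can be read as well: a 1.6-fold higher number from compound 1 to compound 4 (0.20 log units; within the scatter) and a 1.2-fold lower number from compound 3 to compound 4 (0.08 log units; within the scatter) both leave the numbers within the scatter. Among the compounds shown here, by contrast, an at least 3.3-fold lower number from compound 2 to compound 4 (0.52 log units; beyond the scatter) is the only one of the new steps beyond the scatter, so compounds 1, 3 and 4 remain together and apart from compound 2. The value of compound 2 is a limit and not a number: the limit of > 100000 nM in this assay, at which 1 of the 4 values shown sits.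

The compounds shown leave open whether the methoxy group itself or its place on the ring sets compound 2 apart, as 4-methoxyphenyl is not among them. They also leave open how an amine or a carboxylic acid at this position would read.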